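This account rests on a few compounds, and the source may have more. Where it says the series, first, only, none or still open, it means among the compounds named here.

Measured compounds:
compound 1 `CCOC(=O)C1=Cc2ccccc2OC1(OCc1cn(CC(=O)NC2CCCCC2)nn1)C(F)(F)F` — 12100 nM
compound 2 `CCOC(=O)C1=Cc2ccccc2OC1(OCc1cc(-c2ccc3ccccc3c2)no1)C(F)(F)F` — 65400 nM
compound 3 `O=C(O)C1=Cc2ccccc2OC1(OCc1cc(-c2ccc([N+](=O)[O-])cc2)no1)C(F)(F)F` — a limit of the assay, > 150000 nM

In a functional assay on MCF7 cells (Homo sapiens) for inhibition, read by MTT assay, with a stated time of 24 h (on this read-out higher numbers stand for weaker inhibition and lower numbers for stronger inhibition), compound 1 gives 12100 nM, the lowest of the two numbers recorded. Compound 2 gives 65400 nM, a higher number, and the gap between the two lies beyond the usual scatter of this assay. Compound 3 reaches only a limit, > 150000 nM, so no number is known for it; it is one of the values that sit at the limit of > 150000 nM in this assay, at which 1 of the 3 values shown sits.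

Compound 4 `CCOC(=O)C1=Cc2ccccc2OC1(OCc1cn(-c2ccc(F)c([N+](=O)[O-])c2)nn1)C(F)(F)F` has not yet been measured. It differs from compound 1 in one place: 4-fluoro-3-nitrophenyl in place of (cyclohexylcarbamoyl)methyl on an aromatic nitrogen. Among the compounds with values here, nothing measured here shows what such a change on the aromatic nitrogen of the shared core does, since no step between measured compounds alters that position alone, and compounds 2 and 3 carry different rings and a different ester or acid at the same time.

In the absence of a comparable step, compound 4 is expected to land near compound 1, with a wide range on either side, and the step from compound 1 to compound 4 is estimated as a 1.5-fold higher number from compound 1 to compound 4 (0.17 log units; within the scatter). For compound 4 the estimate is 18000 nM, between 5000 nM and 80000 nM.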

Compound 4, half-maximal inhibitory concentration: 16200 nM
Estimate against measurement, compound 4: 1.1-fold (0.05 log units) above, within the range that was stated.
By their numbers in this assay, from the lowest: compounds 1 and 4 (each within the scatter of the next); then compound 2. At a limit, above all of these: compound 3.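

In this assay, putting 4-fluoro-3-nitrophenyl in place of (cyclohexylcarbamoyl)methyl on the aromatic nitrogen gives a 1.3-fold higher number from compound 1 to compound 4 (0.13 log units; within the scatter), the only step shown that alters this position alone. For this pair, then, a group with a hydrogen-bond donor and a six-membered non-aromatic ring and a group with no hydrogen-bond donor and a six-membered aromatic ring, each of 10 heavy atoms, cannot be told apart on this read-out. Nothing on record bears on why the two compounds read alike.

This single pair leaves open what a much smaller group on that nitrogen, such as methyl, or a longer chain ending in an amine would give. It also leaves open how a plain phenyl group would read there, and what a carboxylic acid in place of the ethyl ester would do on the shared core with either of these two groups.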